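The compounds below may be only part of what the source reports. "The series", "measured", "known", "first", "only" and "open" are said of these compounds alone.

Measured in a functional assay on SMMC-7721 cells (Homo sapiens) for inhibition, read by CCK-8 assay, with a stated time of 72 h, tested at 2 uM; on this read-out higher numbers stand for more inhibition of growth at the one concentration tested and lower numbers for less inhibition of growth:
- compound 1 `COc1ccc(SCc2ccc(C(=O)Nc3ccccc3N)cc2)cc1`: 33.1%
- compound 2 `CC(C)(C)c1ccc(SCc2ccc(C(=O)Nc3ccccc3N)cc2)cc1`: 23.6%

In this assay, among the measured compounds shown here, compound 2, at 23.6%, stands within the scatter of compound 1, the only other measured compound. Compound 3 `Nc1ccccc1NC(=O)c1ccc(CSc2ccc(F)cc2)cc1` is still unmeasured and carries this change: fluoro in place of tert-butyl on an aromatic carbon. For the measured compounds named here, one measured step bears on it, tert-butyl in place of methoxy on an aromatic carbon: a number 9.5 percentage points lower from compound 1 to compound 2 (within the scatter). That single step gives no direction, so nothing beyond the scatter is expected. The expected change is a number 4.4 percentage points higher from compound 2 to compound 3 (within the scatter). For compound 3 the estimated value is 28%, with an expected range of 14% to 44%.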

Compound 3, percent growth inhibition at one concentration: 6.58%
The estimate for compound 3 lay 21.4 percentage points above the measured number; measured number outside the range, below it.
By their numbers in this assay, from the lowest: compound 3; then compounds 2 and 1 (each within the scatter of the next).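

In this assay the group on the aromatic carbon para to a large group now matters beyond the scatter: fluoro in place of tert-butyl gives a number 17 percentage points lower from compound 2 to compound 3 (beyond the scatter) and fluoro in place of methoxy gives a number 26.5 percentage points lower from compound 1 to compound 3 (beyond the scatter) in the same series. Compound 3 is thus the lowest of the three, set apart from both compound 1 and compound 2, which stay within the scatter of each other. The data shown offer no explanation for this drop.

As far as these compounds go, whether the low number is particular to fluoro remains open. Chloro, an amine or a carboxylic acid at this place would show whether other groups follow compound 3 or stay with compound 1 and compound 2.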